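Nitro Sulfone Amides With No Measurable Receptor Binding

The compounds below may be only part of what the source reports. "The series", "measured", "known", "first", "only" and "open" are said of these compounds alone.

Compound 2 `CS(=O)(=O)c1ccc(C(=O)NCCC(=O)N2CCCc3ccccc32)cc1[N+](=O)[O-]` was examined in an assay on isolated protein for inhibition of vitamin D3 receptor (Homo sapiens), read by fluorescence polarization; a lower number here means a stronger inhibitor, a higher number a weaker inhibitor. In this assay compound 2 reaches only > 60000 nM, which is a limit of the assay and not a number. Compound 1 `CS(=O)(=O)c1ccc(C(=O)N2CCC(C(=O)N(Cc3ccccc3)c3ccccc3)CC2)cc1[N+](=O)[O-]` gives > 60000 nM in this assay, again a limit. Compound 3 `CCCN(C(=O)CN(C)C(=O)c1ccc(S(C)(=O)=O)c([N+](=O)[O-])c1)c1ccccc1` likewise gives > 60000 nM in this assay, also a limit. Compound 2 therefore stands nowhere distinct among the numbers shown: every measured compound sits at the same limit, as summarised by the limit of > 60000 nM in this assay, at which 3 of the 3 values shown sit. Going by the values given here, no step between two measured compounds can be read, since none of them yields a number.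

Compound 4 `CC(C)N(C(=O)CCNC(=O)c1ccc(S(C)(=O)=O)c([N+](=O)[O-])c1)C(C)C` has not yet been measured in this assay. It differs from compound 2 by diisopropylamino in place of 1,2,3,4-tetrahydroquinolin-1-yl on a carbonyl carbon whose other neighbours are a saturated chain carbon. Among the compounds with values here, with no measured step to lean on, and with compound 2 itself at the limit recorded in the limit of > 60000 nM in this assay, at which 3 of the 3 values shown sit, the step from compound 2 to compound 4 is expected to be a number no higher from compound 2 to compound 4 (the limit leaves the size open), nothing beyond the scatter in either direction. Compound 4 is accordingly estimated at 60000 nM in this assay, within 20000 nM to 200000 nM, and most probably reported once more only as a limit.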

Compound 4, half-maximal inhibitory concentration: > 60000 nM
Compound 4 was reported as a limit (the forecaster's own chance of this, stated with the estimate: 85%); the middle value sits exactly at the limit.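

In this assay compound 4 gives > 60000 nM which is a limit of the assay and not a number. Compound 2 also stands at a limit, so no step can be read between compound 2 and compound 4. The compounds shown leave open whether diisopropylamino in place of 1,2,3,4-tetrahydroquinolin-1-yl on a carbonyl carbon changes binding at all.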